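Trimethoxyphenyl series: indolyl replacement for chlorophenyl

The source may hold more compounds than are shown below. What is called first, only, known or untested is meant among the compounds shown, and "the series" means these compounds.

Measured compounds and their values in a functional assay on B16-F0 cells (Mus musculus) for inhibition, read by CCK-8 assay, with a stated time of 48 h; on this read-out higher numbers stand for weaker inhibition and lower numbers for stronger inhibition:
Compound 1 `COc1cc(-c2ccnc3cc(-c4ccc(C)cc4)nn23)cc(OC)c1OC` gives 21 nM.
Compound 2 `COc1cc(-c2ccnc3cc(-c4ccc(Cl)cc4)nn23)cc(OC)c1OC` gives 4090 nM.
Compound 3 `Cn1ccc2cc(-c3cc4nccc(-c5ccc(F)cc5)n4n3)ccc21` gives 4780 nM.

Compound 2 stands second highest of the three numbers. Its nearest neighbour is compound 3, which sits within the scatter of it, so no order between the two can be claimed; compound 1 lies far lower. Within the data shown here, the one measured step that touches compound 2 is a 190-fold higher number from compound 1 to compound 2 (2.29 log units; beyond the scatter), a large move on this assay from a single change at the aryl group attached to the shared core.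

Compound 4 `COc1cc(-c2ccnc3cc(-c4ccc5ccn(C)c5c4)nn23)cc(OC)c1OC` differs from compound 2 by 1-methyl-1H-indol-6-yl in place of 4-chlorophenyl on an aromatic carbon. Among the measured compounds shown here, no measured pair shows this particular exchange, and compound 3, which carries a related 1-methylindolyl group, differs from compound 2 in more than one place, so only its value stands beside that of compound 2. The large step from compound 1 to compound 2 shows that this position moves the number strongly; the direction for compound 4 is therefore uncertain, and the expected step of a 2.7-fold lower number from compound 2 to compound 4 (0.44 log units; beyond the scatter) is set close to no change with a wide range. Compound 4 is estimated at 1500 nM, between 150 nM and 10000 nM.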

Compound 4, half-maximal inhibitory concentration: 657 nM
Estimate against measurement, compound 4: 2.3-fold (0.36 log units) above, and the stated range covers the measured number.
By their numbers in this assay, from the lowest: compound 1; then compound 4; then compounds 2 and 3 (each within the scatter of the next).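

In this assay, the step of a 6.2-fold lower number from compound 2 to compound 4 (0.79 log units; beyond the scatter) shows that this aromatic carbon accepts a 1-methyl-1H-indol-6-yl group, a fused aromatic group larger than the single-ring aryl groups of compound 1 and compound 2, with a modest gain over 4-chlorophenyl. The step of a 31-fold higher number from compound 1 to compound 4 (1.50 log units; beyond the scatter) shows that this exchange does not match 4-methylphenyl, so across these three compounds the order at this position is 4-methylphenyl, then 1-methyl-1H-indol-6-yl, then 4-chlorophenyl. No supporting data on the origin of this order are available, so it stands only as an observation.

Open, as far as these compounds go, is how an unsubstituted phenyl, or a phenyl carrying an ethyl chain, an amine or a carboxylic acid, would rank at this position. Also open, from the compounds shown here alone, is whether the same order holds on a core other than that of compound 1.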